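The source may report more compounds than this note shows. Statements on the series, on what has been measured and on what is new or still open speak of the compounds shown alone.

Compound 1 `COc1ccc(C2C(OC)C(=O)N2c2cc(OC)c(OC)c(OC)c2)cc1[N+](=O)[O-]` gives in a functional assay on IMR-32 cells (Homo sapiens) for cytotoxicity; on this read-out higher numbers stand for weaker inhibition and lower numbers for stronger inhibition > 1000 nM; > 10000 nM (2 entries). Compound 3 `COc1ccc(C2C(O)C(=O)N2c2cc(OC)c(OC)c(OC)c2)cc1N` gives in this assay 37 nM; 38.3 nM (2 entries). Within the data shown here, compound 2 `COc1ccc(C2C(OC(C)=O)C(=O)N2c2cc(OC)c(OC)c(OC)c2)cc1N` gives in this assay 73.1 nM, a value lying within the scatter of compound 3; it is the only single number for compound 2, two further entries carrying no number at all. Compound 4 `COc1ccc(C2C(OC)C(=O)N2c2cc(OC)c(OC)c(OC)c2)cc1N` differs from compound 2 by methyl in place of acetyl on an oxygen on a saturated carbon. Among the measured compounds shown here, no measured pair shows this change on its own, so the step is expected to be modest, towards weaker inhibition and near the edge of the scatter, with a 2.1-fold higher number from compound 2 to compound 4 (0.31 log units; beyond the scatter). Compound 4 is therefore expected to give 150 nM, within 40 nM to 600 nM.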

Compound 4, half-maximal inhibitory concentration: > 1000 nM
Compound 4: a limit, no number; the forecaster's own chance of this, stated with the estimate: 10%; middle value at least 6.6-fold (0.82 log units) from the limit.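

Exchanging acetoxy for methoxy on an oxygen on a saturated carbon is a large change in this assay, with an at least 13-fold higher number from compound 2 to compound 4 (1.13 log units; beyond the scatter). Compound 4 gives > 1000 nM, which is a limit and not a number. Among the compounds shown, only those carrying methoxy here, compound 1 and compound 4, give limits alone, while compound 2 and compound 3 give numbers. From the compounds shown here alone, how far compound 4 lies past its limit stays open. Also open, going by these compounds, is whether an amine or a longer ester such as propanoyloxy in this place would follow acetoxy or methoxy.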